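This account rests on a few compounds, and the source may have more. Where it says the series, first, only, none or still open, it means among the compounds named here.

Compound 1 `COc1cc(C(=O)c2sc(-c3ccc(F)cc3)cc2N)cc(OC)c1OC` gives 12 nM in a functional assay on MOLT-4 cells (Homo sapiens) for antiproliferative activity; a higher number here means a weaker inhibitor, a lower number a stronger inhibitor; compound 2 `COc1cc(C(=O)c2sc(-c3ccc(C(F)(F)F)cc3)cc2N)cc(OC)c1OC` gives 250 nM; compound 3 `COc1cc(C(=O)c2sc(-c3ccc([N+](=O)[O-])cc3)cc2N)cc(OC)c1OC` gives 110 nM. Compound 3 thus holds the second highest of the three numbers: a 2.3-fold lower number from compound 2 to compound 3 (0.36 log units; beyond the scatter), while a 9.2-fold higher number from compound 1 to compound 3 (0.96 log units; beyond the scatter). Compound 4 `COc1ccc(-c2cc(N)c(C(=O)c3cc(OC)c(OC)c(OC)c3)s2)cc1OC` is not yet measured; it differs from compound 3 by 3,4-dimethoxyphenyl in place of 4-nitrophenyl on an aromatic carbon. Among the compounds with values here, the steps that bear on this change all exchange the group on the same aromatic carbon: a 21-fold higher number from compound 1 to compound 2 (1.32 log units; beyond the scatter) and a 9.2-fold higher number from compound 1 to compound 3 (0.96 log units; beyond the scatter), both beyond the scatter, so this position moves the number strongly. Within the data shown here, no measured step introduces a 3,4-dimethoxyphenyl, so direction is uncertain. For compound 4 the expected step is a 1.8-fold lower number from compound 3 to compound 4 (0.26 log units; within the scatter), and the expected value is 60 nM, within 10 nM to 400 nM.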

Compound 4, half-maximal inhibitory concentration: 20 nM
Beside the measured number, compound 4's estimate is 3.0-fold (0.48 log units) above it; the range from low to high includes it.
By their numbers in this assay, from the lowest: compounds 1 and 4 (each within the scatter of the next); then compound 3; then compound 2.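

At this aromatic carbon, 3,4-dimethoxyphenyl gives a clear gain over both earlier electron-list extremes in the number: a 5.5-fold lower number from compound 3 to compound 4 (0.74 log units; beyond the scatter) and a 13-fold lower number from compound 2 to compound 4 (1.10 log units; beyond the scatter). Against 4-fluorophenyl there is a 1.7-fold higher number from compound 1 to compound 4 (0.22 log units; within the scatter), so 3,4-dimethoxyphenyl and 4-fluorophenyl cannot be ordered in this assay, and a change from 4-fluorophenyl need not raise the number as trifluoromethyl and nitro did. Nothing available explains these steps. Open, on these data alone, is whether one methoxy group alone would suffice, and which of the two matters. An amine or a carboxylic acid on this phenyl ring also remains untested in the compounds shown.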